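A few compounds are considered here, and "the series" means these few. Any claim that something is new, unique, unknown or untested is made for them only; others in the source may bear on it.

Measured in a functional assay on KB cells (Homo sapiens) for antiproliferative activity, read by sulforhodamine B assay, with a stated time of 3 days; a lower number here means that less compound is needed, a higher number that more compound is needed for the effect:
Compound 1 `CCC1=C(O)c2c(oc(-c3ccc(O)cc3)cc2=O)C(CC)(CC)C1=O`: 20.6 uM
Compound 2 `CCC1=C(O)c2c(oc(-c3ccc(OC)cc3)cc2=O)C(CC)(CC)C1=O`: 17.7 uM
Compound 3 `CCC1=C(O)c2c(oc(-c3cccc(C)c3)cc2=O)C(CC)(CC)C1=O`: 49.7 uM

Compound 3 has the highest number of the three, so it needs the most compound for the effect. Compound 4 `CCC1=C(O)c2c(oc(-c3ccccc3OC)cc2=O)C(CC)(CC)C1=O` differs from it in one place: 2-methoxyphenyl in place of 3-methylphenyl on an aromatic carbon. The nearest evidence is a 2.8-fold higher number from compound 2 to compound 3 (0.45 log units; beyond the scatter), where 3-methylphenyl replaces 4-methoxyphenyl. The step of a 2.4-fold higher number from compound 1 to compound 3 (0.38 log units; beyond the scatter) is of similar size. For the measured compounds named here, no measured compound carries 2-methoxyphenyl, so this comparison is only a rough guide. A modest move back towards compound 2 therefore seems likely in this assay. The expected step is a 1.8-fold lower number from compound 3 to compound 4 (0.26 log units; within the scatter). For compound 4 the estimated value is 27 uM, with an expected range of 12 uM to 60 uM.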

Compound 4, concentration for half-maximal effect: 40.8 uM
Compound 4: the middle estimate sits 1.5-fold (0.18 log units) below what was measured; the measured number falls inside the stated range.
By their numbers in this assay, from the lowest: compounds 2, 1, 4 and 3 (each within the scatter of the next, the first and the last beyond it).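

On this aromatic carbon, next to the ring oxygen, 2-methoxyphenyl and 4-methoxyphenyl do not behave alike in this assay, which shows a 2.3-fold higher number from compound 2 to compound 4 (0.36 log units; beyond the scatter) as the step between them. Against 3-methylphenyl the new group brings no clear change, with a 1.2-fold lower number from compound 3 to compound 4 (0.09 log units; within the scatter) as the step, and the comparison with 4-hydroxyphenyl, a 2.0-fold higher number from compound 1 to compound 4 (0.30 log units; within the scatter) also stays within the scatter. No measurement at hand explains these steps.

Still open, going by these compounds, is what an amine or a carboxylic acid on this phenyl ring would do to the number. On these data alone, whether any group here can go much lower than compound 2 also remains unknown.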